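Swapping the basic amine for a benzoate ester: cytotoxicity expected

This account rests on a few compounds, and the source may have more. Where it says the series, first, only, none or still open, it means among the compounds named here.

Compounds measured in an ADME assay on HEK293-A cells (Homo sapiens) for cytotoxicity, read by MTT assay, with a stated time of 48 h; a higher number here means a weaker inhibitor, a lower number a stronger inhibitor:
Compound 1, `CN1CCN(C[C@H]2CN(c3ccc(-n4cc(-c5ccccn5)cn4)c(F)c3)C(=O)O2)CC1`, gives 70 ug/mL.
Compound 2, `O=C1O[C@@H](CN2CCC(O)CC2)CN1c1ccc(-n2cc(-c3ccccn3)cn2)c(F)c1`, reaches only the limit of the measurement, > 400 ug/mL.
Compound 3, `O=C1CNC(=O)N1C[C@H]1CN(c2ccc(-n3cc(-c4ccccn4)cn3)c(F)c2)C(=O)O1`, likewise reaches only the limit, > 400 ug/mL.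

Compound 1 is the only one of the three with an actual number; the other two sit at the limit of > 400 ug/mL in this assay, at which 2 of the 3 values shown sit. Compound 4, `O=C(OC[C@H]1CN(c2ccc(-n3cc(-c4ccccn4)cn3)c(F)c2)C(=O)O1)c1ccccc1`, has not been measured. It differs from compound 1 in one place: benzoyloxy in place of 4-methylpiperazin-1-yl on a saturated chain carbon bound to a saturated ring carbon.

Two measured steps start from the same place on compound 1 and both replace the 4-methylpiperazin-1-yl group. The change to compound 2 gave an at least 5.7-fold higher number from compound 1 to compound 2 (0.75 log units; beyond the scatter), and the change to compound 3 gave an at least 5.7-fold higher number from compound 1 to compound 3 (0.75 log units; beyond the scatter). In both cases the number rose out of reach of the assay, so the size of the step cannot be read in full. The step from compound 2 to compound 3, a step that the two limits leave unreadable from compound 2 to compound 3, adds nothing further. Among the compounds with values here, no measured step introduces a benzoyloxy group, so the expectation for compound 4 rests only on the shared direction of these two replacements.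

Compound 4 is therefore expected to show a weaker effect than compound 1, a step of about a 3.6-fold higher number from compound 1 to compound 4 (0.55 log units; beyond the scatter), with a fair chance that this assay again reports only a limit. The estimate for compound 4 is 250 ug/mL, within a range from 70 ug/mL to 400 ug/mL.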

Compound 4, half-maximal inhibitory concentration: > 400 ug/mL
Compound 4 gave a limit, no number; the forecaster's own chance of this, stated with the estimate: 50%; at least 1.6-fold (0.20 log units) between middle value and limit.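

Benzoyloxy in place of 4-methylpiperazin-1-yl on a saturated chain carbon bound to a saturated ring carbon gives an at least 5.7-fold higher number from compound 1 to compound 4 (0.75 log units; beyond the scatter), so all three replacements shown at this place move the same way, and none goes against that direction. Both 4-hydroxypiperidin-1-yl and 2,5-dioxoimidazolidin-1-yl hold nitrogen, whereas benzoyloxy holds only carbon and oxygen and carries an aromatic ring, so the rise in this assay does not depend on a nitrogen ring taking the place of 4-methylpiperazin-1-yl. The steps among compound 2, compound 3 and compound 4 cannot be read, so no order among these three replacements follows, and compound 1 remains the only compound with an actual number: the limit of > 400 ug/mL in this assay, at which 3 of the 4 values shown sit.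

As far as these compounds go, it remains open whether the lower number of compound 1 belongs to 4-methylpiperazin-1-yl alone or would also appear with another amine at this place, such as morpholine or a dimethylamino group. A carboxylic acid or a plain alkyl chain on the same carbon could show whether any replacement lands at a readable number between compound 1 and the limit.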